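Swapping sulfamoyl for acetyl on compound 2

A few compounds are considered here, and "the series" means these few. Any claim that something is new, unique, unknown or untested is made for them only; others in the source may bear on it.

In an ADME assay (liver) for metabolic stability, with Liver microsome (Rattus norvegicus) as the target, using microsomes and NADPH, with a stated time of 30 min (on this read-out lower numbers stand for slow clearance and higher numbers for fast clearance), compound 1 `CC#C[C@H]1CN(S(=O)(=O)c2ccc(N)nc2)CCN1c1ncc(C(C)(O)C(F)(F)F)s1` gives 87 mL.min-1.g-1 while compound 2 `CC#C[C@H]1CN(S(=O)(=O)c2ccc(N)nc2)CCN1c1ccc(S(N)(=O)=O)cc1` gives 30 mL.min-1.g-1 and compound 3 `CC#C[C@H]1CN(S(=O)(=O)c2ccc(N)nc2)CCN1c1ccc(C(C)(O)C(F)(F)F)nc1` gives 31 mL.min-1.g-1 on the same scale. Compound 2 and compound 3 sit within the scatter of each other, and compound 1 lies beyond the scatter above compound 2. Compound 4 `CC#C[C@H]1CN(S(=O)(=O)c2ccc(N)nc2)CCN1c1ccc(C(C)=O)cc1` carries acetyl in place of sulfamoyl on an aromatic carbon. For the measured compounds named here, no measured pair shows this exchange, so any forecast is loose. A moderate rise in clearance is expected, only a little beyond the scatter, and no real change remains possible. The estimated step of a 2.0-fold higher number from compound 2 to compound 4 (0.30 log units; within the scatter) reflects that modest rise. For compound 4 the estimated value is 60 mL.min-1.g-1 with an expected range from 25 mL.min-1.g-1 to 140 mL.min-1.g-1 as its span.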

Compound 4, intrinsic clearance in microsomes: 249 mL.min-1.g-1
Estimate against measurement, compound 4: 4.2-fold (0.62 log units) below; the whole stated range lies below it.
By their numbers in this assay, from the lowest: compounds 2 and 3 (each within the scatter of the next); then compound 1; then compound 4.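

On an aromatic carbon para to a large group, acetyl in place of sulfamoyl gives an 8.3-fold higher number from compound 2 to compound 4 (0.92 log units; beyond the scatter) in this assay and is therefore far from a neutral exchange. For the compounds shown here, this pair is the first to differ in one place, so it ties a large step to this single change. No measurement offered here accounts for the rise. Still open, going by these compounds, is whether the rise follows from gaining acetyl or from losing sulfamoyl. A nitrile or a carboxylic acid on the same carbon would help separate these two readings.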